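A few compounds are considered here, and "the series" means these few. Any claim that something is new, unique, unknown or untested is made for them only; others in the source may bear on it.

Of the compounds shown here, two have values so far. Compound 1 `COc1ccc2nc(C)cc(NC(=O)C(=O)Nc3cc(C)cc(C)c3)c2c1` gives 10000 nM in a physicochemical assay for solubility, in phosphate buffer, measured as kinetic solubility, with a stated time of 1 h, at pH 7.4; a lower number here means a less soluble compound, a higher number a more soluble compound. Compound 2 `COc1ccc2nc(C)cc(OCC(=O)Nc3c(C)cccc3C)c2c1` gives 112000 nM, the higher of the two numbers, and the gap between compound 1 and compound 2 lies beyond the usual scatter. Compound 3 `COc1ccc2nc(C)cc(OCC(=O)Nc3cc(C)nc(C)n3)c2c1` remains unmeasured. The change from compound 2 to compound 3 is 2,6-dimethylpyrimidin-4-yl in place of 2,6-dimethylphenyl on an amide-type nitrogen. Among the measured compounds shown here, no measured pair shows this kind of step, so the direction rests on expectation alone. A modest rise, a 1.8-fold higher number from compound 2 to compound 3 (0.25 log units; within the scatter), is expected for compound 3. The value of compound 3 is estimated at 200000 nM, within 80000 nM to 500000 nM.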

Compound 3, solubility: 5000 nM
Estimate against measurement, compound 3: 40-fold (1.60 log units) above; measured number below the stated range.
By their numbers in this assay, from the lowest: compounds 3 and 1 (each within the scatter of the next); then compound 2.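

On the amide-type nitrogen, 2,6-dimethylpyrimidin-4-yl in place of 2,6-dimethylphenyl gives a 22-fold lower number from compound 2 to compound 3 (1.35 log units; beyond the scatter) in this assay. Among the compounds shown here, this is the first one-place comparison, and it shows that the read-out is sensitive to the ring at this position, even when the swap involves only ring atoms. Nothing available accounts for the size of this step.

From the compounds shown here alone, it remains open whether both ring nitrogens are needed for this step. A pyridyl group, or a phenyl ring carrying an amine, at this position would test that.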